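Cyclopropyl in place of 3-methoxycyclobutyl: an expected half-life

The source may hold more compounds than are shown below. What is called first, only, known or untested is meant among the compounds shown, and "the series" means these compounds.

In an ADME assay (Canis lupus familiaris, strain Beagle) for metabolic stability (on this read-out higher numbers stand for a longer-lived compound and lower numbers for a shorter-lived compound), compound 2 (`CCn1c(-c2cnc(C)nc2)nc2c(N[C@H]3CCN(C(=O)[C@H]4C[C@@H](OC)C4)C3)ncnc21`) gives 4.3 h. That value lies within the scatter of compound 1 (`CCn1c(-c2cnc(C)nc2)nc2c(O[C@H]3CCN(C(=O)C4CCOC4)C3)ncnc21`), which gives 3.8 h, while compound 3 (`CCn1c(-c2cnc(C)nc2)nc2c(O[C@H]3CCN(C(=O)C4CC4)C3)ncnc21`) gives a clearly lower 1.3 h. Compound 4 (`CCn1c(-c2cnc(C)nc2)nc2c(N[C@H]3CCN(C(=O)C4CC4)C3)ncnc21`) has not yet been measured. It differs from compound 2 in one place, on a carbonyl carbon, where cyclopropyl takes the place of 3-methoxycyclobutyl: cyclopropyl in place of 3-methoxycyclobutyl on a carbonyl carbon.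

Going by the values given here, one measured step bears on this change: a 2.9-fold lower number from compound 1 to compound 3 (0.47 log units; beyond the scatter), where cyclopropyl takes the place of oxolan-3-yl on a carbonyl carbon. It is only a partial guide, as a different group leaves there and the core of compound 1 is not the core of compound 2. The expectation in this assay is a step of similar size in the same direction, an estimated 2.9-fold lower number from compound 2 to compound 4 (0.46 log units; beyond the scatter). Compound 4 is expected at 1.5 h, with an estimated range of 0.8 h to 3 h.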

Compound 4, half-life: 4.7 h
Compound 4: the middle estimate sits 3.1-fold (0.50 log units) below what was measured; the whole stated range lies below it.
By their numbers in this assay, from the lowest: compound 3; then compounds 1, 2 and 4 (each within the scatter of the next).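

In this assay, the change of 3-methoxycyclobutyl to cyclopropyl on a carbonyl carbon gives a 1.1-fold higher number from compound 2 to compound 4 (0.04 log units; within the scatter), so on the core of compound 2 the six heavy atoms of the larger group can be replaced by the three of cyclopropyl with no shift beyond the scatter. The drop seen when cyclopropyl replaced oxolan-3-yl on the core of compound 1 therefore does not hold as a general feature of cyclopropyl at this place: compound 3 gives 1.3 h and compound 4, with the same cyclopropylcarbonyl on a different core, gives 4.7 h here. Nothing in the data explains why the cyclopropyl result differs between these two cores.

Going by these compounds, whether oxolan-3-yl on the core of compound 2 would match these values remains open. So does the outcome for a smaller methyl or an amine-bearing chain on the same carbonyl carbon.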